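Swapping the Ring on the Thiocarbonyl Carbon

The compounds below may be only part of what the source reports. "The series", "measured", "known", "first", "only" and "open" are said of these compounds alone.

Measured compounds:
- compound 1, `Cc1cccc(/C(N)=N/NC(=S)N2CCSCC2)n1`: 54.6%
- compound 2, `Cc1cccc(/C(N)=N/NC(=S)N2CCOCC2)n1`: 65.7%
- compound 3, `Cc1cccc(/C(N)=N/NC(=S)N2CCCCC2)n1`: 68.9%

These three compounds share one core and differ only in the saturated ring attached to the thiocarbonyl carbon. In a functional assay on HeLa cells (Homo sapiens) for cytotoxicity, read by MTT assay, with a stated time of 72 h, tested at 3 uM (on this read-out lower numbers stand for less inhibition of growth and higher numbers for more inhibition of growth at the one concentration tested), compound 3 shows the highest of the three numbers, but its separation from compound 2 is small: a number 3.2 percentage points higher from compound 2 to compound 3 (within the scatter). Only the gap to compound 1 counts, a number 14.3 percentage points higher from compound 1 to compound 3 (beyond the scatter), and compound 2 also sits above compound 1 by a number 11.1 percentage points higher from compound 1 to compound 2 (beyond the scatter).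

Compound 4, `Cc1cccc(/C(N)=N/NC(=S)N2CCCC2)n1`, is the next variation: pyrrolidin-1-yl in place of piperidin-1-yl on a thiocarbonyl carbon. Among the measured compounds shown here, no measured step removes a ring atom in this way, so the closest guide is the swap between compound 2 and compound 3, which stayed within the scatter, while the two swaps away from compound 1 were modest. A small shift, if any, is therefore expected for compound 4 in this assay, with the step of a number 4.9 percentage points lower from compound 3 to compound 4 (within the scatter) estimated to fall inside the scatter. Compound 4 is expected to give about 64%, within a range from 50% to 78%.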

Compound 4, percent growth inhibition at one concentration: 56.8%
Compound 4: middle estimate off by 7.2 percentage points, on the high side, within the range that was stated.
By their numbers in this assay, from the lowest: compounds 1, 4, 2 and 3 (each within the scatter of the next, the first and the last beyond it).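

In this assay the size of the ring on the thiocarbonyl carbon matters: moving to the five-membered pyrrolidin-1-yl gives a number 12.1 percentage points lower from compound 3 to compound 4 (beyond the scatter) and so costs growth inhibition. Among the compounds shown here, both rings carry only the one nitrogen, so this is the first step in which ring size changes with no change of hetero atom. The other two steps give a number 8.9 percentage points lower from compound 2 to compound 4 (within the scatter) and a number 2.2 percentage points higher from compound 1 to compound 4 (within the scatter) as well, which leaves compound 4 inseparable from either compound 2 or compound 1, even though those two stand apart from each other.

Nothing available explains why the smaller ring behaves this way. As far as these compounds go, it also remains open whether a larger ring such as azepan-1-yl, or an open-chain dimethylamino group, would hold the level of compound 3 or fall further.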